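The source may report more compounds than this note shows. Statements on the series, on what has been measured and on what is new or still open speak of the compounds shown alone.

Of the compounds shown here, three built on one shared core have been measured in a functional assay, with a stated time of 15 min; a higher number here means that more compound is needed for the effect, a lower number that less compound is needed. Compound 1 `CCCCCCCCCC(=O)Nc1ccc(O)c2ccccc12` gives 18000 nM, and compound 2 `CCC(=O)Nc1ccc(O)c2ccccc12` gives 16000 nM; between them the change is a 1.1-fold lower number from compound 1 to compound 2 (0.05 log units; within the scatter). Compound 3 `N#Cc1ccc(N)c2ccccc12`, which carries an amino group and a nitrile rather than the amide and the hydroxy group, gives 1000000 nM. Compound 2 therefore sits within the scatter of compound 1, while compound 3 gives a far higher number.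

Compound 4 `CN(C)c1ccc(O)c2ccccc12` differs from compound 2 by dimethylamino in place of propanoylamino on an aromatic carbon. For the measured compounds named here, no measured step bears directly on this change: the step from compound 1 to compound 2 only shortens the chain while the amide itself is kept, and compound 3 differs from compound 2 in more than one place. Because compound 3, which also has no amide, gives 1000000 nM, a higher number is expected for compound 4, though with wide uncertainty. Compound 4 is expected to give 40000 nM, between 8000 nM and 200000 nM, which means an estimated step of a 2.5-fold higher number from compound 2 to compound 4 (0.40 log units; beyond the scatter).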

Compound 4, half-maximal effective concentration: 18000 nM
Estimate against measurement, compound 4: 2.2-fold (0.35 log units) above, within the range that was stated.
By their numbers in this assay, from the lowest: compounds 2, 1 and 4 (each within the scatter of the next); then compound 3.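

In this assay, replacing propanoylamino with dimethylamino gives a 1.1-fold higher number from compound 2 to compound 4 (0.05 log units; within the scatter), so this aromatic carbon, para to a hydroxy group, tolerates the loss of the amide with the number remaining within the scatter. The earlier one-place step kept the amide and altered only the chain, whereas this one removes both the carbonyl and the amide hydrogen. No measured evidence accounts for this result.

The compounds shown leave open how a plain amino group, a carboxylic acid or a longer dialkylamino group would read at this position. They also leave open what replacing the hydroxy group alone would do, as compound 3 differs from compound 2 in more than one place.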